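This account rests on a few compounds, and the source may have more. Where it says the series, first, only, none or still open, it means among the compounds named here.

Measured so far, in an assay on isolated protein (strain Sprague-Dawley) for inhibition of Amine oxidase [flavin-containing] A (Rattus norvegicus), read by spectrophotometry, with a stated time of 5 min, tested at 10 uM; a lower number here means less inhibition, a higher number more inhibition at the concentration tested (going by the name of the read-out):

Compound 1, `CC(C)Oc1cc(=O)oc2cc(OCc3cccc(Cl)c3)ccc12`, gives 3%.
Compound 2, `CC(=O)COc1cc(=O)oc2cc(OCc3cccc(Cl)c3)ccc12`, gives 22%.
Compound 3, `O=c1cc(Oc2ccccc2)c2ccc(OCc3cccc(Cl)c3)cc2o1`, gives 0%.

Compound 3 sits lowest of these three numbers. Its nearest neighbour is compound 1, a few points higher but within the scatter, so the two cannot be told apart; its furthest is compound 2, beyond the scatter, as the step of a number 22 percentage points lower from compound 2 to compound 3 (beyond the scatter) shows. The new compound 4, `N#Cc1cc(=O)oc2cc(OCc3cccc(Cl)c3)ccc12`, differs from compound 3 in one place: cyano in place of phenoxy on an aromatic carbon.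

All three measured steps change the group at this same position. Replacing isopropyl with 2-oxopropyl on an oxygen on an aromatic ring gave a number 19 percentage points higher from compound 1 to compound 2 (beyond the scatter), while phenyl in place of isopropyl gave a number 3 percentage points lower from compound 1 to compound 3 (within the scatter). Among the compounds with values here, no measured step swaps phenoxy for cyano, so the direction is open; the spread seen so far suggests at most a modest move. For compound 4 the estimate is 10%, between 0% and 30%, an expected step of a number 10 percentage points higher from compound 3 to compound 4 (within the scatter).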

Compound 4, a percentage reported as inhibition, at one concentration (the size of the read-out at that concentration, not a potency): 23%
Compound 4: the middle estimate sits 13 percentage points below what was measured, and the stated range covers the measured number.
By their numbers in this assay, from the lowest: compounds 3 and 1 (each within the scatter of the next); then compounds 2 and 4 (each within the scatter of the next).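

In this assay, cyano in place of phenoxy gives a number 23 percentage points higher from compound 3 to compound 4 (beyond the scatter) and cyano in place of isopropoxy gives a number 20 percentage points higher from compound 1 to compound 4 (beyond the scatter) on this aromatic carbon, so a reading beyond the scatter of those two compounds does not require an oxygen link at this position. Cyano in place of 2-oxopropoxy gives a number 1 percentage points higher from compound 2 to compound 4 (within the scatter) and shows that a small group with no ring and a carbonyl-bearing chain cannot be told apart here, although they share neither size nor shape. No measurement shown explains why these groups read as they do.

From the compounds shown here alone, it stays open how an amine, a carboxylic acid or an amide on this aromatic carbon would read. A longer chain on the oxygen is equally untested among these compounds, and so is whether any of these readings would hold as a potency.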